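Swapping a Thiophene Ring for a Methoxyphenyl Ring

The compounds below may be only part of what the source reports. "The series", "measured", "known", "first", "only" and "open" are said of these compounds alone.

Of the compounds shown here, three built on one shared core have been measured in a functional assay on DU-145 cells (Homo sapiens) for inhibition, read by trypan blue exclusion, with a stated time of 96 h; a higher number here means a weaker inhibitor of growth, a lower number a stronger inhibitor of growth. Compound 1 `CCOc1ccc(/C=C(/SCc2ccc(C)cc2)C(=O)c2ccc(Cl)cc2)cc1OC` gives 25000 nM in this assay. Compound 3 `Cc1ccc(S/C(=C/c2ccc(F)cc2C(F)(F)F)C(=O)c2ccc(Br)cc2)cc1` gives 25000 nM. Compound 2 `COc1ccsc1/C=C(\C(=O)c1ccc(Br)cc1)S(=O)(=O)Cc1ccc(Cl)cc1` gives 50000 nM, the highest of the three numbers, though its gap to compound 1 and to compound 3 lies within the usual scatter of such measurements, so the three cannot be ranked against one another on these data.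

Compound 4 `COc1ccc(/C=C(\C(=O)c2ccc(Br)cc2)S(=O)(=O)Cc2ccc(Cl)cc2)cc1` has not yet been measured. It differs from compound 2 in one place: 4-methoxyphenyl in place of 3-methoxythiophen-2-yl on a double-bonded chain carbon bound to a double-bonded chain carbon. Among the compounds with values here, no pair of measured compounds shows what this exact change does, so its effect is unknown from the data. The three measured compounds all sit close together, and compound 2 gives 50000 nM as the starting point. On this basis the step from compound 2 to compound 4 is expected to be a 1.4-fold lower number from compound 2 to compound 4 (0.15 log units; within the scatter), that is, nothing beyond the scatter in either direction. Compound 4 is therefore estimated at 35000 nM in this assay, within a range from 12000 nM to 100000 nM.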

Compound 4, concentration for 50% growth inhibition: 25000 nM
Estimate against measurement, compound 4: 1.4-fold (0.15 log units) above; measured number inside the range.
By their numbers in this assay, from the lowest: compounds 1, 3, 4 and 2 (each within the scatter of the next).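

Within the data shown here, this is the first measured pair that differs in one place only: in this assay, 4-methoxyphenyl in place of 3-methoxythiophen-2-yl on a double-bonded chain carbon bound to a double-bonded chain carbon gives a 2.0-fold lower number from compound 2 to compound 4 (0.30 log units; within the scatter). At this position, then, a five-membered aromatic ring with a sulfur atom and a six-membered aromatic ring of carbon only cannot be told apart, which compounds 1 and 3, differing from compound 2 in several places at once, could not show. The data offer no explanation for this result.

Still open, going by these compounds, is whether a different kind of group at this place would give a step beyond the scatter. A ring carrying an amine or a carboxylic acid in place of the methoxy group would test this.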